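Cyclohexyl in place of methyl: an expected outcome

The source may report more compounds than this note shows. Statements on the series, on what has been measured and on what is new or still open speak of the compounds shown alone.

compound 1 `COC(=O)c1nc(C)n(-c2ccc(C(F)(F)F)cc2)n1`: 16600 nM
compound 2 `COC(=O)c1nc(C)n(-c2ccc(F)cc2)n1`: 11700 nM

In a functional assay on NCI-H226 cells (Homo sapiens) for inhibition, read by MTT assay, with a stated time of 72 h (on this read-out higher numbers stand for weaker inhibition of growth and lower numbers for stronger inhibition of growth), compound 1 gives 16600 nM, the highest of the two numbers shown. Compound 2 gives 11700 nM, and the step is a 1.4-fold lower number from compound 1 to compound 2 (0.15 log units; within the scatter). Compound 3 `COC(=O)c1nc(C2CCCCC2)n(-c2ccc(C(F)(F)F)cc2)n1` differs from compound 1 by cyclohexyl in place of methyl on an aromatic carbon. For the measured compounds named here, no measured step bears on this change: the only step recorded concerns the group on the phenyl ring, not the methyl. With nothing to set a direction, the step is expected to be a 1.4-fold lower number from compound 1 to compound 3 (0.14 log units; within the scatter), no larger than the scatter. For compound 3 the estimate is 12000 nM, with a range from 3000 nM to 45000 nM.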

Compound 3, concentration for 50% growth inhibition: 5760 nM
Estimate against measurement, compound 3: 2.1-fold (0.32 log units) above; the range from low to high includes it.
By their numbers in this assay, from the lowest: compound 3; then compounds 2 and 1 (each within the scatter of the next).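

In this assay, the aromatic carbon between two ring nitrogen atoms proves responsive: cyclohexyl in place of methyl gives a 2.9-fold lower number from compound 1 to compound 3 (0.46 log units; beyond the scatter), the only step shown that lies beyond the scatter. This position therefore accepts a cyclohexyl ring with no loss of growth inhibition. Nothing available gives a reason for this step.

Going by these compounds, whether the gain is specific to cyclohexyl remains open, as a phenyl ring or a longer chain on this carbon would show. On these data alone, it is also open whether the step holds with fluoro in place of trifluoromethyl, or with a carboxylic acid in place of the methoxycarbonyl group.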